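A few compounds are considered here, and "the series" means these few. Any claim that something is new, unique, unknown or untested is made for them only; others in the source may bear on it.

In a functional assay on MGC-803 cells (Homo sapiens) for antiproliferative activity, read by MTT assay, with a stated time of 72 h (on this read-out higher numbers stand for weaker inhibition and lower numbers for stronger inhibition), compound 3 `O=C(NO)c1ccc(NCc2nc(-c3cc4ccccc4s3)nn2-c2ccccc2)cc1` gives 6110 nM. This is level, within the scatter, with compound 1 `O=C(NO)c1ccc(NCc2nc(-c3cccc(Cl)c3)nn2-c2ccccc2)cc1` at 5760 nM and compound 2 `O=C(NO)c1ccc(NCc2nc(-c3ccc(Cl)cc3)nn2-c2ccccc2)cc1` at 5970 nM. Compound 4 `Cc1cccc(-c2nc(CNc3ccc(C(=O)NO)cc3)n(-c3ccccc3)n2)c1` changes the same aromatic carbon, between two ring nitrogen atoms: 3-methylphenyl in place of 1-benzothiophen-2-yl on an aromatic carbon. Three measured steps exchange the group at this place: a 1.0-fold higher number from compound 1 to compound 2 (0.02 log units; within the scatter), a 1.1-fold higher number from compound 1 to compound 3 (0.03 log units; within the scatter) and a 1.0-fold higher number from compound 2 to compound 3 (0.01 log units; within the scatter), all within the scatter. For the measured compounds named here, the 3-methylphenyl group itself has no measured precedent. On those three steps, no change beyond the scatter is expected in this assay, in either direction. The expected step is a 1.0-fold lower number from compound 3 to compound 4 (0.01 log units; within the scatter). For compound 4 the estimated value is 6000 nM, with an expected range of 3200 nM to 11000 nM.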

Compound 4, half-maximal inhibitory concentration: 8710 nM
Estimate against measurement, compound 4: 1.5-fold (0.16 log units) below, and the stated range covers the measured number.
By their numbers in this assay, from the lowest: compounds 1, 2, 3 and 4 (each within the scatter of the next).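

Against every earlier group, the 3-methylphenyl group stays within the scatter in this assay (a 1.4-fold higher number from compound 3 to compound 4 (0.15 log units; within the scatter)) (a 1.5-fold higher number from compound 2 to compound 4 (0.16 log units; within the scatter)), so this aromatic carbon accepts a carbon-only aryl group without a step beyond the scatter. The direct exchange of methyl for chloro (a 1.5-fold higher number from compound 1 to compound 4 (0.18 log units; within the scatter)) is also within the scatter, so chloro is not required at this place among these compounds. No measured evidence bears on these steps. From the compounds shown here alone, all four groups here are aromatic, so it remains open how this position responds to an amine, a carboxylic acid or a longer alkyl chain.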